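Swapping the aryl group on a fluorinated bicyclic glutamate analogue

The compounds below may be only part of what the source reports. "The series", "measured", "known", "first", "only" and "open" are said of these compounds alone.

Of the compounds shown here, two have been measured in an assay on CHO cells for binding affinity to metabotropic glutamate receptor 2 (Rattus norvegicus); on this read-out higher numbers stand for weaker inhibition and lower numbers for stronger inhibition. Compound 1 `CO[C@@H]1C[C@@H]2[C@H]([C@]1(N)C(=O)O)[C@@]2(F)C(=O)O` gives 39.2 nM. Compound 2 `N[C@]1(C(=O)O)[C@H]2[C@@H](C[C@H]1OCc1cc(F)cc(F)c1)[C@]2(F)C(=O)O` gives 12.4 nM, the lowest of the two numbers, and the step of a 3.2-fold lower number from compound 1 to compound 2 (0.50 log units; beyond the scatter) places compound 2 apart from compound 1 beyond the scatter.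

Compound 3 `N[C@]1(C(=O)O)[C@H]2[C@@H](C[C@H]1OCc1cc(Cl)ccc1Cl)[C@]2(F)C(=O)O` has not yet been measured in this assay. It differs from compound 2 in one place: 2,5-dichlorophenyl in place of 3,5-difluorophenyl on a saturated chain carbon bound to an oxygen on a saturated carbon. Going by the values given here, the only measured step, from compound 1 to compound 2, introduced an aryl group where hydrogen had been; no measured pair exchanges one aryl group for another, so the size of this step rests on no direct precedent. The change keeps the ring and its two halogens while moving their positions and replacing fluorine by chlorine, and such a rearrangement is expected to leave the number near that of compound 2, with no step beyond the scatter in either direction.

Compound 3 is therefore expected to give about 12 nM in this assay, within a range from 3.5 nM to 40 nM, an expected step of a 1.0-fold lower number from compound 2 to compound 3 (0.01 log units; within the scatter).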

Compound 3, inhibition constant: 11.8 nM
For compound 3 the middle estimate is 1.0-fold (0.01 log units) above the measured one, within the range that was stated.
By their numbers in this assay, from the lowest: compounds 3 and 2 (each within the scatter of the next); then compound 1.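

In this assay, 2,5-dichlorophenyl in place of 3,5-difluorophenyl on a saturated chain carbon bound to an oxygen on a saturated carbon gives a 1.1-fold lower number from compound 2 to compound 3 (0.02 log units; within the scatter), so at this position the two aryl groups, which differ in their halogen and its placement on the ring, cannot be told apart on this read-out. Placing 2,5-dichlorophenyl where hydrogen had been gives a 3.3-fold lower number from compound 1 to compound 3 (0.52 log units; beyond the scatter), and 3,5-difluorophenyl at the same place gives a 3.2-fold lower number from compound 1 to compound 2 (0.50 log units; beyond the scatter), so a step beyond the scatter is now seen with two aryl groups rather than one. No independent measurement is available to explain why these two aryl groups read alike.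

Both aryl groups carry two halogens, which leaves open whether an unsubstituted phenyl, a phenyl with a single chlorine, or a ring bearing a nitrile or a methoxy group would read the same at this position. As far as these compounds go, it also remains open whether a pyridine in place of the phenyl, or a longer chain between the oxygen and the ring, would stay level with compound 2 and compound 3 or move apart from them.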